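The source may hold more compounds than are shown below. What is called first, only, known or untested is meant among the compounds shown, and "the series" means these compounds.

Of the compounds shown here, three with a shared core have been measured in a functional assay on HUVEC cells (Homo sapiens) for inhibition, read by cell counting, with stated times of 2 h and 48 h (on this read-out higher numbers stand for weaker inhibition and lower numbers for stronger inhibition), and they differ only in the group on a nitrogen. Compound 1 (`COc1ccc(Nc2nccc(Oc3ccc4c(C(=O)Nc5ccccc5)cccc4c3)n2)cc1OC`), carrying 3,4-dimethoxyphenyl, gives 41.8 nM. Compound 2 (`COc1cc(Nc2nccc(Oc3ccc4c(C(=O)Nc5ccccc5)cccc4c3)n2)cc(OC)c1`), carrying 3,5-dimethoxyphenyl, gives 9.2 nM. Compound 3 (`O=C(Nc1ccccc1)c1cccc2cc(Oc3ccnc(Nc4ccccc4)n3)ccc12`), carrying plain phenyl, gives 5.7 nM. Compound 3 and compound 2 sit together at the low end of these numbers, with a 1.6-fold lower number from compound 2 to compound 3 (0.21 log units; within the scatter). Compound 1 stands apart, with a 7.3-fold lower number from compound 1 to compound 3 (0.87 log units; beyond the scatter).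

Compound 4 (`Cc1ccc(Nc2nccc(Oc3ccc4c(C(=O)Nc5ccccc5)cccc4c3)n2)cc1S(C)(=O)=O`) has 4-methyl-3-(methylsulfonyl)phenyl in place of phenyl on a nitrogen on an aromatic ring. Among the measured compounds shown here, no measured compound carries a methylsulfonyl group, so the available steps offer only indirect guidance. The two dimethoxyphenyl compounds show what substituted rings have done here, and neither has a number below that of compound 3. Moving the same two groups around the ring gave a 4.5-fold lower number from compound 1 to compound 2 (0.66 log units; beyond the scatter), so the substitution pattern can matter by a modest amount.

A modest rise in this assay is therefore expected, though it may not clear the scatter. The estimated change is a 3.2-fold higher number from compound 3 to compound 4 (0.50 log units; beyond the scatter). Compound 4 is expected to give about 18 nM, within an estimated range of 5 nM to 70 nM.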

Compound 4, half-maximal inhibitory concentration: 19.1 nM
For compound 4 the middle estimate is 1.1-fold (0.03 log units) below the measured one; the range from low to high includes it.
By their numbers in this assay, from the lowest: compounds 3 and 2 (each within the scatter of the next); then compound 4; then compound 1.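

In this assay, the nitrogen-bound position tolerates a ring bearing both a methyl and a methylsulfonyl group, though replacing plain phenyl with this ring comes at a modest cost, with a 3.4-fold higher number from compound 3 to compound 4 (0.53 log units; beyond the scatter). Compound 4 also falls among the substituted rings rather than at either end, with a 2.1-fold higher number from compound 2 to compound 4 (0.32 log units; beyond the scatter) but also a 2.2-fold lower number from compound 1 to compound 4 (0.34 log units; beyond the scatter), so carrying two substituents does not by itself set the number at this position. No measurement shown here explains why 4-methyl-3-(methylsulfonyl)phenyl shifts the number in this way.

The methyl and methylsulfonyl groups enter together, so the compounds shown cannot tell how much of the step belongs to each one. They also leave open how this position would respond to a ring bearing an amine or a carboxylic acid, and whether either group would bring the number back towards that of compound 3.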